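Ethoxy to isobutoxy: working notes on compound 3

The source may hold more compounds than are shown below. What is called first, only, known or untested is meant among the compounds shown, and "the series" means these compounds.

In a functional assay on THP-1 cells (Homo sapiens) for inhibition, read by sulforhodamine B assay, with a stated time of 48 h (on this read-out lower numbers stand for stronger inhibition and higher numbers for weaker inhibition), compound 1 `CCO[C@H]1C[C@@H](c2coc3ccc(F)cc3c2=O)N(c2ccccc2)O1` reaches only a limit of the assay, > 60000 nM. Going by the values given here, compound 2 `CCO[C@H]1C[C@@H](c2coc3ccc(C)cc3c2=O)N(c2ccccc2)O1` gives 41000 nM, the only actual number so far. Compound 3 `Cc1ccc2occ([C@@H]3C[C@H](OCC(C)C)ON3c3ccccc3)c(=O)c2c1` differs from it by isopropyl in place of methyl on a saturated chain carbon bound to an oxygen on a saturated carbon. Among the compounds with values here, the sole measured step, an at least 1.4-fold lower number from compound 1 to compound 2 (0.16 log units; that floor lies within the scatter), is methyl in place of fluoro on an aromatic carbon, elsewhere on the molecule, so it offers little guidance. No change beyond the scatter is expected in this assay. The expected step is a 1.2-fold lower number from compound 2 to compound 3 (0.07 log units; within the scatter). For compound 3 the estimate is 35000 nM, with an expected range of 15000 nM to 60000 nM.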

Compound 3, half-maximal inhibitory concentration: 21500 nM
Estimate against measurement, compound 3: 1.6-fold (0.21 log units) above, within the range that was stated.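

In this assay, ethoxy to isobutoxy gives a 1.9-fold lower number from compound 2 to compound 3 (0.28 log units; within the scatter). Going by these compounds alone, this is the first reading at this position, since the earlier step concerned an aromatic carbon, and it shows isopropyl in place of methyl here with no change beyond the scatter. Compound 1 remains a limit of the assay, not a number: the limit of > 60000 nM in this assay, at which 1 of the 3 values shown sits.

On these data alone, whether any group at this position can move the number beyond the scatter stays open. A longer chain, an amine or a carboxylic acid in place of isobutoxy would address that question.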